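The source may report more compounds than this note shows. Statements on the series, on what has been measured and on what is new or still open speak of the compounds shown alone.

Compound 1 `COC(=O)c1ccc(-c2cn(CC(=O)Nc3nc(C)cs3)nn2)cc1` — in a functional assay on BMDM cells (Mus musculus, strain C57BL/6) for inhibition, with a stated time of 2 days (a higher number here means a weaker inhibitor, a lower number a stronger inhibitor), compound 1 reaches only the assay limit > 30000 nM (the limit of > 30000 nM in this assay, at which 1 of the 3 values shown sits).
Compound 2 `COc1ccc(-c2cn(CC(=O)Nc3nc(C)cs3)nn2)cc1` — in this assay compound 2 gives 3890 nM.
Compound 3 `Cc1csc(NC(=O)Cn2cc(-c3ccncc3)nn2)n1` — in this assay compound 3 gives 100 nM.

Compound 3 stands lowest of the two numbers available; compound 2 is the nearest, well beyond the scatter, and compound 1 sits at a limit. Among the measured compounds shown here, the single measured step, an at least 7.7-fold lower number from compound 1 to compound 2 (0.88 log units; beyond the scatter), concerns only the substituent on the six-membered aromatic ring of carbon only and shows that such a change moves the number beyond the scatter.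

Compound 4 `Cc1csc(NC(=O)Cn2cc(-c3ccc(F)cc3)nn2)n1` is not yet measured. It differs from compound 3 in 4-fluorophenyl in place of pyridin-4-yl on an aromatic carbon. For the measured compounds named here, no measured step exchanges pyridin-4-yl for a ring of carbon only, so the closest guide is the pair of compound 3, which carries pyridin-4-yl, and compound 2, which carries a substituted six-membered aromatic ring of carbon only: compound 3 gives 100 nM, and compound 2 gives 3890 nM. A higher number is therefore expected for compound 4 in this assay, a step of a 15-fold higher number from compound 3 to compound 4 (1.18 log units; beyond the scatter). The estimate for compound 4 is 1500 nM, with a range from 300 nM to 8000 nM.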

Compound 4, half-maximal inhibitory concentration: 250 nM
Estimate against measurement, compound 4: 6.0-fold (0.78 log units) above; measured number below the stated range.
By their numbers in this assay, from the lowest: compound 3; then compound 4; then compound 2. At a limit, above all of these: compound 1.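

In this assay the exchange of pyridin-4-yl for 4-fluorophenyl gives only a 2.5-fold higher number from compound 3 to compound 4 (0.40 log units; beyond the scatter), so a six-membered aromatic ring of carbon only can still give a low number at this position. The group carried on that ring accounts for much larger differences: fluoro in place of methoxy gives a 16-fold lower number from compound 2 to compound 4 (1.19 log units; beyond the scatter), and fluoro in place of methoxycarbonyl gives an at least 120-fold lower number from compound 1 to compound 4 (2.07 log units; beyond the scatter). Compound 1 stands only at a limit, so this last step is a bound: the limit of > 30000 nM in this assay, at which 1 of the 4 values shown sits.

Still open, on these data alone, is how an unsubstituted phenyl, or an amine or a carboxylic acid on the ring of carbon only, would compare with fluoro. Also open is whether a change elsewhere on the shared core would move the number, since all the compounds shown keep that core unchanged.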